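This account rests on a few compounds, and the source may have more. Where it says the series, first, only, none or still open, it means among the compounds named here.

Compound 1, `Cc1c(CC(=O)O)c2ccsc2n1S(=O)(=O)c1ccc(S(C)(=O)=O)cc1`, is the stronger of the two compounds measured in an assay on HEK293 cells for displacement of a labelled ligand from prostaglandin D2 receptor 2 (Homo sapiens) (on this read-out lower numbers stand for stronger inhibition and higher numbers for weaker inhibition), giving 90 nM. For the measured compounds named here, its only measured neighbour, compound 2, `Cc1c(CC(=O)O)c2ccsc2n1S(=O)(=O)c1ccc(S(=O)(=O)N2CCOCC2)cc1`, differs from it on the sulfonyl sulfur, where morpholin-4-yl replaces methyl; in this assay compound 2 gives 230 nM, and the step of a 2.6-fold higher number from compound 1 to compound 2 (0.41 log units; beyond the scatter) is a modest one that lies beyond the scatter. Compound 3, `Cc1csc2c1c(CC(=O)O)c(C)n2S(=O)(=O)c1ccc(S(C)(=O)=O)cc1`, is the next compound to be measured in this assay. It differs from compound 1 by methyl in place of hydrogen on an aromatic carbon. Going by the values given here, no measured step touches this place on the core of compound 1: the one step in hand, from compound 1 to compound 2, concerns a group on the sulfonyl sulfur and has no bearing on a change at the aromatic carbon of the fused ring system. With the addition being a single carbon atom on the core, the account therefore expects a step no larger than the scatter, written as a 1.1-fold higher number from compound 1 to compound 3 (0.05 log units; within the scatter). On this basis compound 3 is estimated at 100 nM in this assay, with a range from 40 nM to 250 nM.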

Compound 3, half-maximal inhibitory concentration: 1300 nM
Compound 3: middle estimate off by 13-fold (1.11 log units), on the low side; the whole stated range lies below it.
By their numbers in this assay, from the lowest: compound 1; then compound 2; then compound 3.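

In this assay this aromatic carbon, two ring bonds from the ring sulfur, proves sensitive to substitution: methyl in place of hydrogen gives a 14-fold higher number from compound 1 to compound 3 (1.16 log units; beyond the scatter) for a single added carbon atom. This is larger than a 2.6-fold higher number from compound 1 to compound 2 (0.41 log units; beyond the scatter) on the sulfonyl sulfur, so of the two changes in hand, the smaller one, on the core, is the one that weakens inhibition more. Nothing available bears on why a methyl at this place has so large an effect.

The compounds shown carry only hydrogen and methyl at this carbon, so it remains open whether the loss belongs to methyl alone or to any group here, and whether a chlorine atom, a hydroxymethyl group or a longer chain such as ethyl would fall near compound 1 or near compound 3. Also open, going by these compounds, is whether the same methyl would weigh as heavily with the morpholin-4-yl group of compound 2 on the sulfonyl sulfur, and whether the other carbon atoms of this five-membered ring respond in the same way.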